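The source may report more compounds than this note shows. Statements on the series, on what has been measured and on what is new or still open speak of the compounds shown alone.

Measured in an ADME assay on microsomes from liver (Homo sapiens) for metabolic stability, with a stated time of 30 min; on this read-out higher numbers stand for a more stable compound and lower numbers for a less stable compound:
compound 1 `CCCCc1nc(C)c(CC(=O)OC)c(=O)n1Cc1ccc(-c2ccccc2-c2noc(=O)[nH]2)cc1`: 69.6%
compound 2 `CCCCOC(=O)Cc1c(C)nc(CCCC)n(Cc2ccc(-c3ccccc3-c3noc(=O)[nH]3)cc2)c1=O`: 2.8%
compound 3 `CCCCc1nc(C)c(CC(=O)OCC2CCCCC2)c(=O)n1Cc1ccc(-c2ccccc2-c2noc(=O)[nH]2)cc1`: 11.5%

Compound 3 stands second highest of the three: a number 8.7 percentage points higher from compound 2 to compound 3 (within the scatter), while a number 58.1 percentage points lower from compound 1 to compound 3 (beyond the scatter). Compound 4 `CC#CCOC(=O)Cc1c(C)nc(CCCC)n(Cc2ccc(-c3ccccc3-c3noc(=O)[nH]3)cc2)c1=O` differs from compound 3 in one place: prop-1-yn-1-yl in place of cyclohexyl on a saturated chain carbon bound to an oxygen next to a carbonyl group. Among the measured compounds shown here, two measured steps bear on this. a number 66.8 percentage points lower from compound 1 to compound 2 (beyond the scatter) and a number 58.1 percentage points lower from compound 1 to compound 3 (beyond the scatter); both large drops come from replacing hydrogen at that position with a carbon group. Between two such carbon groups, a number 8.7 percentage points higher from compound 2 to compound 3 (within the scatter). Since compound 4 again carries a carbon group there, the expected step of a number 4.5 percentage points lower from compound 3 to compound 4 (within the scatter) is small, within the scatter. For compound 4 in this assay the estimate is 7%, with a range from 1% to 22%.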

Compound 4, percent of the compound remaining: 32%
Beside the measured number, compound 4's estimate is 25 percentage points below it, outside the stated range (above it).
By their numbers in this assay, from the lowest: compounds 2 and 3 (each within the scatter of the next); then compound 4; then compound 1.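

In this assay, carbon groups on a saturated chain carbon bound to an oxygen next to a carbonyl group are not interchangeable: prop-1-yn-1-yl gives a number 20.5 percentage points higher from compound 3 to compound 4 (beyond the scatter) and a number 29.2 percentage points higher from compound 2 to compound 4 (beyond the scatter), although cyclohexyl and propyl lie within the scatter of each other. Hydrogen at this place still stands apart, with a number 37.6 percentage points lower from compound 1 to compound 4 (beyond the scatter). Nothing measured here explains what sets the group with the triple bond apart.

Still open, going by these compounds, is how a longer chain carrying a triple bond would behave at this place, and how a chain ending in an amine would compare.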